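This account rests on a few compounds, and the source may have more. Where it says the series, first, only, none or still open, it means among the compounds named here.

Compound 1 `Cc1nc2ccc(NC(=O)COc3ccc(OC(F)(F)F)cc3)cn2c1C`: 3.8 nM
Compound 2 `Cc1oc2ccc(NC(=O)COc3ccc(OC(F)(F)F)cc3)cc2c1C`: > 1000 nM
Compound 3 `Cc1c(C2CC2)nc2ccc(-n3ccc(OCc4ccccc4)cc3=O)cn12`: 42 nM

Of the compounds shown here, three have been measured in an assay on CHO cells for displacement of a labelled ligand from melanin-concentrating hormone receptor 1 (Homo sapiens), read by scintillation counting, with a stated time of 1 h; on this read-out lower numbers stand for stronger inhibition and higher numbers for weaker inhibition. Compound 1 gives 3.8 nM. The value of compound 2 is a limit of the assay and not a number: the limit of > 1000 nM in this assay, at which 1 of the 3 values shown sits. Compound 3 gives 42 nM, which is the higher of the two numbers in this assay, with compound 1 giving the lower number; the gap between them lies beyond the usual scatter. Within the data shown here, compound 2 shares no single-point relationship with either of the others, and no measured pair differs in only one place, so no step size has been read directly.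

Compound 4 `Cc1c(C2CC2)nc2ccc(-n3ccc(OCc4csc(C(F)(F)F)c4)cc3=O)cn12` has not yet been measured. It differs from compound 3 by 5-(trifluoromethyl)thiophen-3-yl in place of phenyl on a saturated chain carbon bound to an oxygen on an aromatic ring. Among the measured compounds shown here, no measured pair covers a change of this kind, so the expected size of the step from compound 3 to compound 4 rests on the structural change alone; the expectation is a step of a 1.1-fold lower number from compound 3 to compound 4 (0.02 log units; within the scatter), not clearly beyond the scatter in either direction. On that basis compound 4 is estimated at 40 nM in this assay, within a range of 12 nM to 130 nM.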

Compound 4, half-maximal inhibitory concentration: 17 nM
Estimate against measurement, compound 4: 2.4-fold (0.37 log units) above; the range from low to high includes it.
By their numbers in this assay, from the lowest: compound 1; then compound 4; then compound 3. At a limit, above all of these: compound 2.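

In this assay, among these compounds, putting 5-(trifluoromethyl)thiophen-3-yl in place of phenyl on a saturated chain carbon bound to an oxygen on an aromatic ring gives a 2.5-fold lower number from compound 3 to compound 4 (0.39 log units; beyond the scatter), and this is the first step that can be read between compounds differing in one place. It shows that this place accepts a five-membered aromatic ring with one hetero atom and a trifluoromethyl group where a six-membered aromatic ring of carbon only stood, and that the number falls by more than the usual scatter. No measurement shown speaks to the reason for this step.

The compounds shown leave open whether the step belongs to the thiophene ring or to the trifluoromethyl group, since a plain thiophen-3-yl or a phenyl carrying trifluoromethyl would be needed to separate the two. Also open, on these data alone, is whether the same exchange would act alike on other cores, because compound 1 and compound 2 each differ from compound 3 and compound 4 in more than one place, so steps to them cannot be read.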